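Losing the Furan Ring From Compound 2

The compounds below may be only part of what the source reports. "The series", "measured", "known", "first", "only" and "open" are said of these compounds alone.

Measured in an ADME assay on MRC5 cells (Homo sapiens), read by MTT assay, with a stated time of 3 days; on this read-out lower numbers stand for stronger inhibition and higher numbers for weaker inhibition:
Compound 1 `CN(C)c1ncnc2[nH]cc(Sc3cccs3)c12`: > 150000 nM, a limit of the assay
Compound 2 `c1coc(-c2ncnc3[nH]cc(Sc4cccs4)c23)c1`: 32900 nM

For the measured compounds named here, compound 2 carries the only actual number in this pair, 32900 nM. The other result, (the limit of > 150000 nM in this assay, at which 1 of the 2 values shown sits), belongs to compound 1 and is a limit. Compound 3 `Cc1ncnc2[nH]cc(Sc3cccs3)c12` keeps the shared core and differs from compound 2 in one group: methyl in place of furan-2-yl on an aromatic carbon. Going by the values given here, one measured step bears on this change: an at least 4.5-fold lower number from compound 1 to compound 2 (0.65 log units; beyond the scatter). That step brought the furan-2-yl in, while the step to compound 3 takes it out, although the incoming methyl is not the dimethylamino of compound 1. The number in this assay is therefore expected to rise, by a modest amount beyond the scatter, and it may reach the limit. The estimate amounts to a 2.4-fold higher number from compound 2 to compound 3 (0.39 log units; beyond the scatter), an expected weakening. Compound 3 is expected at 80000 nM, within an estimated range of 35000 nM to 180000 nM.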

Compound 3, half-maximal inhibitory concentration: 136000 nM
Compound 3: middle estimate off by 1.7-fold (0.23 log units), on the low side; the measured number falls inside the stated range.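

In this assay methyl in place of furan-2-yl gives a 4.1-fold higher number from compound 2 to compound 3 (0.62 log units; beyond the scatter) and this change is read between two actual numbers rather than against a limit. The lower number of compound 2 therefore goes with the furan-2-yl itself, and not only with the absence of dimethylamino. Compound 1 stands at > 150000 nM as a limit of the assay: the limit of > 150000 nM in this assay, at which 1 of the 3 values shown sits.

Read against that limit, the data give an at least 1.1-fold lower number from compound 1 to compound 3 (0.04 log units; that floor lies within the scatter) and so establish no difference for this pair.

As far as these compounds go, whether another ring in this place, such as phenyl or thiophen-2-yl, would keep the number near that of compound 2 remains open, and so does whether the ring oxygen of the furan-2-yl matters. What an ethyl group, a longer chain or a primary amine would do on this aromatic carbon also stays unknown, since only three groups are shown here.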